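Swapping the aryl group on a shared cyanopyridinone core

The source may report more compounds than this note shows. Statements on the series, on what has been measured and on what is new or still open speak of the compounds shown alone.

Compound 1 `COc1ccc(-c2cc(-c3cc(C(C)C)c(O)cc3C)[nH]c(=O)c2C#N)c(OC)c1` gives, in a functional assay for inhibition, tested at 40 ug/mL (a higher number here means a stronger effect of the compound at the concentration tested, a lower number a weaker effect), 37.5%. Compound 2 `COc1cc(-c2cc(-c3cc(C(C)C)c(O)cc3C)[nH]c(=O)c2C#N)ccc1O` gives, in this assay, 32%. Among the measured compounds shown here, the single measured step, a number 5.5 percentage points lower from compound 1 to compound 2 (within the scatter), leaves both numbers within the scatter of each other, so compound 2 stands next to the only other measured number without a real difference between them.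

Compound 3 `Cc1cc(O)c(C(C)C)cc1-c1cc(-c2ccc(N(C)C)cc2)c(C#N)c(=O)[nH]1` has not yet been measured. Its change from compound 2 is 4-(dimethylamino)phenyl in place of 4-hydroxy-3-methoxyphenyl on an aromatic carbon. For the measured compounds named here, the one measured step alters the same aryl group and was within the scatter, which suggests this position tolerates changes of this sort without a large shift; no measured step involves a dimethylamino group, so the evidence is thin. A change of a number 1 percentage points higher from compound 2 to compound 3 (within the scatter) is expected, that is, none beyond the scatter. Compound 3 is therefore estimated at 33%, with a range from 15% to 52%.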

Compound 3, a percentage reported as inhibition, at one concentration (the size of the read-out at that concentration, not a potency): 43%
Estimate against measurement, compound 3: 10 percentage points below, and the stated range covers the measured number.
By their numbers in this assay, from the lowest: compounds 2, 1 and 3 (each within the scatter of the next, the first and the last beyond it).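

In this assay the 4-(dimethylamino)phenyl group gives a number 11 percentage points higher from compound 2 to compound 3 (beyond the scatter) against 4-hydroxy-3-methoxyphenyl, so swapping the aryl group at this position can move the read-out past the scatter, which the earlier step did not show. Against 2,4-dimethoxyphenyl the same group gives a number 5.5 percentage points higher from compound 1 to compound 3 (within the scatter) and so compound 3 stands clearly apart only from compound 2, not from both earlier compounds. Nothing available here offers an explanation for the larger step.

As far as these compounds go, the larger step removes a hydroxy group and a methoxy group and brings in a dimethylamino group all at once, so which of these parts carries the difference stays open. From the compounds shown here alone, how a plain phenyl, a 4-aminophenyl or a 4-(diethylamino)phenyl group would compare is also open, and every reading shows only the size of the effect at a single concentration.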